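The source may hold more compounds than are shown below. What is called first, only, known or untested is meant among the compounds shown, and "the series" means these compounds.

Measured compounds in the series:
- compound 1, `CC#CC(CC(=O)O)c1ccc(OCc2ccn3cc(-c4ccc(C)cc4C)nc3c2)cc1`, 503 nM
- compound 2, `CC#CC(CC(=O)O)c1ccc(OCc2ccn3cc(-c4ccc(CC)cc4)nc3c2)cc1`, 671 nM
- compound 3, `CC#CC(CC(=O)O)c1ccc(OCc2ccn3cc(-c4ccccc4C)nc3c2)cc1`, 459 nM

All three share one core and differ only in the phenyl group on the five-membered ring. In an assay on isolated protein for agonist activity at Free fatty acid receptor 1 (Homo sapiens) (a lower number here means that less compound is needed, a higher number that more compound is needed for the effect), compound 3 gives the lowest of the three numbers, but its gaps to the others are within the scatter: a 1.1-fold lower number from compound 1 to compound 3 (0.04 log units; within the scatter) and a 1.5-fold lower number from compound 2 to compound 3 (0.16 log units; within the scatter). The remaining pair is likewise flat, a 1.3-fold higher number from compound 1 to compound 2 (0.13 log units; within the scatter). Across these three compounds the substitution pattern of the phenyl group has not moved the read-out beyond the scatter.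

Compound 4, `CC#CC(CC(=O)O)c1ccc(OCc2ccn3cc(-c4ccc(C(F)(F)F)cc4)nc3c2)cc1`, is the next step from compound 3: 4-(trifluoromethyl)phenyl in place of 2-methylphenyl on an aromatic carbon. Among the measured compounds shown here, the steps that bear on it are the two that swap the phenyl substituent, from compound 2 to compound 3 and from compound 1 to compound 3, both within the scatter. For the measured compounds named here, no measured compound carries a trifluoromethyl group, so that part of the change is untested. On the measured steps alone, no change beyond the scatter is expected in this assay, with the step expected as a 1.1-fold higher number from compound 3 to compound 4 (0.05 log units; within the scatter). Compound 4 is therefore estimated at 520 nM, within the range 230 nM to 1200 nM.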

Compound 4, half-maximal effective concentration: 674 nM
The estimate for compound 4 lay 1.3-fold (0.11 log units) below the measured number; low and high end bracket the measured number.
By their numbers in this assay, from the lowest: compounds 3, 1, 2 and 4 (each within the scatter of the next).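

In this assay, among the compounds shown here, the first fluorine-bearing group, 4-(trifluoromethyl)phenyl, stays within the scatter of the earlier phenyl groups (a 1.5-fold higher number from compound 3 to compound 4 (0.17 log units; within the scatter); a 1.3-fold higher number from compound 1 to compound 4 (0.13 log units; within the scatter)). The closest comparison, trifluoromethyl in place of ethyl on an aromatic carbon (a 1.0-fold higher number from compound 2 to compound 4 (0.00 log units; within the scatter)), does not separate the two groups, so the flat picture at this place now extends to a substituent containing atoms other than carbon and hydrogen. Nothing available bears on why the read-out stays flat here.

Still open, on these data alone, is whether any group at this place moves the read-out beyond the scatter, for example an amine, a morpholine or a longer alkoxy chain on the phenyl group. As far as these compounds go, whether changes elsewhere on the shared core are as flat also remains open.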